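Spiro diamine in place of hydroxymethylpiperidine on the core

A few compounds are considered here, and "the series" means these few. Any claim that something is new, unique, unknown or untested is made for them only; others in the source may bear on it.

In an assay on Sf9 cells for inhibition of Leucine-rich repeat serine/threonine-protein kinase 2 (Homo sapiens), read by TR-FRET, with stated times of 30 min and 2 h (a higher number here means a weaker inhibitor, a lower number a stronger inhibitor), compound 1 `O=C(Nc1ccnnc1)c1cc(N2CCC(O)CC2)ccc1OCc1ccccc1` gives 39.8 nM and compound 2 `O=C(Nc1ccnnc1)c1cc(N2CCC(CO)CC2)ccc1OCc1ccccc1` gives 20 nM. For the measured compounds named here, the step of a 2.0-fold lower number from compound 1 to compound 2 (0.30 log units; within the scatter) is the only measured step; compound 2 holds the lowest of the two numbers, with compound 1 nearest, and the gap between them is within the scatter, so no order between them is claimed. Compound 3 `CN1CC2(CCN(c3ccc(OCc4ccccc4)c(C(=O)Nc4ccnnc4)c3)CC2)C1` carries the change (a group of 10 heavy atoms (8 carbon, 2 nitrogen; one four-membered non-aromatic ring with 1 hetero atom, one six-membered non-aromatic ring with 1 hetero atom) in place of a group of 8 heavy atoms (6 carbon, 1 nitrogen, 1 oxygen; one six-membered non-aromatic ring with 1 hetero atom), on an aromatic carbon). Going by the values given here, the one measured step bears on it only loosely: it sits at the same position and shows that altering the substituent on the saturated ring moved the number within the scatter, but it does not cover loss of the hydrogen-bond donor or the group that enters. No step beyond the scatter is therefore expected for compound 3 in this assay, the estimated step being a 1.3-fold lower number from compound 2 to compound 3 (0.10 log units; within the scatter). Compound 3 is expected at 16 nM, within 5 nM to 60 nM.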

Compound 3, half-maximal inhibitory concentration in the Leucine-rich repeat serine/threonine-protein kinase 2 assay: 63.1 nM
Compound 3: the middle estimate sits 3.9-fold (0.60 log units) below what was measured; measured number outside the range, above it.
By their numbers in the Leucine-rich repeat serine/threonine-protein kinase 2 assay, from the lowest: compounds 2, 1 and 3 (each within the scatter of the next, the first and the last beyond it).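

For the compounds shown here, in the Leucine-rich repeat serine/threonine-protein kinase 2 assay this position proves sensitive to the group that enters: the spiro diamine gives a 3.2-fold higher number from compound 2 to compound 3 (0.50 log units; beyond the scatter), the only step beyond the scatter. Against the smaller hydroxy-bearing group the same diamine gives a 1.6-fold higher number from compound 1 to compound 3 (0.20 log units; within the scatter), so a group with no hydrogen-bond donor and a second ring is accepted here at a modest cost at most. In a physicochemical assay for lipophilicity, at pH 7.4 (a lower number here means a more polar compound, a higher number a more lipophilic compound), compound 2 gives 3.5 and compound 3 gives 2.2 as the change moves a second property at this position: the measured distribution coefficient of compound 2, 3.5, and of compound 3, 2.2, a number 1.30 log units lower (beyond the scatter)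

Open, as far as these compounds go, is whether the step in the Leucine-rich repeat serine/threonine-protein kinase 2 assay goes with the four-membered ring or with the loss of the hydroxymethyl group. A primary amine or a carboxylic acid on the six-membered ring, with no second ring, would help separate the two.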